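A few compounds are considered here, and "the series" means these few. Any claim that something is new, unique, unknown or untested is made for them only; others in the source may bear on it.

- compound 1 `COc1cc(NC(C)CCCNC(=O)NNC(=O)Nc2ccc(Cl)cc2)c2ncccc2c1`: 120000 nM
- compound 2 `COc1cc(NC(C)CCCNC(=O)NNC(=O)Nc2ccc(Br)cc2)c2ncccc2c1`: 101000 nM

In a functional assay on HeLa cells (Homo sapiens) for inhibition, read by MTT assay, with a stated time of 72 h (a higher number here means a weaker inhibitor, a lower number a stronger inhibitor), compound 2 gives 101000 nM, level with compound 1 within the scatter. Compound 3 `COc1cc(NC(C)CCCNC(=O)NNC(=O)Nc2cccc(C(F)(F)F)c2)c2ncccc2c1` differs from compound 2 as follows: 3-(trifluoromethyl)phenyl in place of 4-bromophenyl on an amide-type nitrogen. This places 3-(trifluoromethyl)phenyl in place of 4-bromophenyl on an amide-type nitrogen. Within the data shown here, the only measured step is a 1.2-fold lower number from compound 1 to compound 2 (0.07 log units; within the scatter), from bromo in place of chloro on an aromatic carbon. It does not test the incoming group, so the estimate stays wide. The expected change is a 1.4-fold lower number from compound 2 to compound 3 (0.16 log units; within the scatter), with no shift beyond the scatter anticipated. For compound 3 the estimated value is 70000 nM, with an expected range of 18000 nM to 160000 nM.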

Compound 3, half-maximal inhibitory concentration: 4900 nM
Estimate against measurement, compound 3: 14-fold (1.15 log units) above, and the stated range ends above it.
By their numbers in this assay, from the lowest: compound 3; then compounds 2 and 1 (each within the scatter of the next).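

In this assay, the group on the amide-type nitrogen turns out to control the read-out: 3-(trifluoromethyl)phenyl in place of 4-bromophenyl gives a 21-fold lower number from compound 2 to compound 3 (1.31 log units; beyond the scatter) and in place of 4-chlorophenyl gives a 24-fold lower number from compound 1 to compound 3 (1.39 log units; beyond the scatter) on the same nitrogen. The bromo for chloro swap had shown no movement beyond the scatter, so only the larger change reveals that this position responds. Nothing at hand speaks to the cause of this step.

The compounds shown leave open whether the trifluoromethyl group or its place on the ring carries the step, since both change at once. As far as these compounds go, how an unsubstituted phenyl or a nitrile-bearing phenyl would read on this nitrogen also stays open.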